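From Phenyl to Amino on the Shared Core

The compounds below may be only part of what the source reports. "The series", "measured", "known", "first", "only" and "open" are said of these compounds alone.

Three inhibitors of the shared core of compound 1 `C[C@@H]1CCCN1c1c(C#N)c2c(N)nc(Nc3cn[nH]c3)nc2n1C` have been characterised in an assay on isolated protein for inhibition of Leucine-rich repeat serine/threonine-protein kinase 2 (Homo sapiens), read by TR-FRET and LanthaScreen, with stated times of 50 min and 30 min, in the presence of a further agent that is not named here; on this read-out higher numbers stand for weaker inhibition and lower numbers for stronger inhibition. Compound 1 gives 6 nM. Compound 2 `C[C@@H]1CCCN1c1c(C#N)c2c(N)ncnc2n1C` gives 15 nM, and the step of a 2.5-fold higher number from compound 1 to compound 2 (0.40 log units; beyond the scatter) accompanies the change hydrogen in place of (1H-pyrazol-4-yl)amino on an aromatic carbon. Compound 3 `Cn1c(-c2ccccc2)c(C#N)c2c(N)ncnc21` gives 1260 nM, the highest of the three numbers; the step of an 84-fold higher number from compound 2 to compound 3 (1.92 log units; beyond the scatter) follows phenyl in place of 2-methylpyrrolidin-1-yl on an aromatic carbon.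

Compound 4 `Cn1c(N)c(C#N)c2c(N)ncnc21` is not yet measured. It differs from compound 3 by amino in place of phenyl on an aromatic carbon. Among the compounds with values here, only one measured step bears on this position, an 84-fold higher number from compound 2 to compound 3 (1.92 log units; beyond the scatter), which shows that the phenyl of compound 3 carries a far weaker inhibition than a nitrogen-linked ring at the same place. Amino is again nitrogen-linked but much smaller, so a return toward the number of compound 2 is plausible yet far from certain. Compound 4 is therefore expected to show a step of a 6.3-fold lower number from compound 3 to compound 4 (0.80 log units; beyond the scatter) in this assay, toward stronger inhibition. The estimate for compound 4 is 200 nM, with a range from 30 nM to 1500 nM.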

Compound 4, half-maximal inhibitory concentration: 14400 nM
Compound 4: the middle estimate sits 72-fold (1.86 log units) below what was measured; the measured number lies above the stated range.
By their numbers in this assay, from the lowest: compound 1; then compound 2; then compound 3; then compound 4.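

At this position, on an aromatic carbon of the five-membered ring, a nitrogen link alone does not carry the inhibition: in this assay the change from 2-methylpyrrolidin-1-yl to amino gives a 960-fold higher number from compound 2 to compound 4 (2.98 log units; beyond the scatter) and is the largest step among these compounds. The earlier compounds shown here left room for reading compound 3 as weak simply for lacking a nitrogen-linked group, but an 11-fold higher number from compound 3 to compound 4 (1.06 log units; beyond the scatter) shows that phenyl, with its carbon-only ring, stands ahead of amino. The three groups at this place therefore rank 2-methylpyrrolidin-1-yl first, then phenyl, then amino, and nothing shown here explains that order.

These compounds do not separate the nitrogen link from the number of heavy atoms it carries, a question that small nitrogen-linked groups such as methylamino, dimethylamino or an unsubstituted pyrrolidin-1-yl would address. Within the data shown here, also open is whether the (1H-pyrazol-4-yl)amino group, seen only with 2-methylpyrrolidin-1-yl on the shared core, would shift the numbers in the same direction alongside phenyl or amino.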